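Amide nitrogen variation on a shared dihydroxy-acid core

The compounds below may be only part of what the source reports. "The series", "measured", "known", "first", "only" and "open" are said of these compounds alone.

Measured so far in a functional assay on L6 cells (Rattus norvegicus) for inhibition; on this read-out higher numbers stand for weaker inhibition and lower numbers for stronger inhibition:
compound 1 `CCN(Cc1ccccc1)C(=O)c1nn(-c2ccc(F)cc2)c(OC[C@@H](O)C[C@@H](O)CC(=O)O)c1C(C)C` gives 2660 nM
compound 2 `Cc1ccccc1CNC(=O)c1nn(-c2ccc(F)cc2)c(OC[C@@H](O)C[C@@H](O)CC(=O)O)c1C(C)C` gives 2850 nM
compound 3 `COc1cccc(CNC(=O)c2nn(-c3ccc(F)cc3)c(OC[C@@H](O)C[C@@H](O)CC(=O)O)c2C(C)C)c1` gives 8750 nM

Compound 1 carries the lowest number of the three, but compound 2 stays within the scatter of it: a 1.1-fold higher number from compound 1 to compound 2 (0.03 log units; within the scatter). Among the compounds with values here, the only step beyond the scatter is toward compound 3: a 3.3-fold higher number from compound 1 to compound 3 (0.52 log units; beyond the scatter), and a 3.1-fold higher number from compound 2 to compound 3 (0.49 log units; beyond the scatter).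

Compound 4 `Cc1cccc(CN(C)C(=O)c2nn(-c3ccc(F)cc3)c(OC[C@@H](O)C[C@@H](O)CC(=O)O)c2C(C)C)c1` is not yet measured. It differs from compound 1 by methyl(3-methylbenzyl)amino in place of benzyl(ethyl)amino on a carbonyl carbon.

Within the data shown here, two steps bear on it. The move from compound 1 to compound 2, which also changes the amide nitrogen substitution, stays within the scatter. The move from compound 2 to compound 3, which exchanges 2-methylphenyl for 3-methoxyphenyl on the chain carbon bound to the amide-type nitrogen, gives a modest rise in this assay. Compound 4 keeps two substituents on the nitrogen, as in compound 1, but adds a methyl on the benzyl ring in the manner of compound 3. A modest rise is therefore expected: a 1.6-fold higher number from compound 1 to compound 4 (0.20 log units; within the scatter). Compound 4 is estimated at 4200 nM, range 1600 nM to 11000 nM.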

Compound 4, half-maximal inhibitory concentration: 18500 nM
Compound 4: the middle estimate sits 4.4-fold (0.64 log units) below what was measured, outside the stated range (above it).
By their numbers in this assay, from the lowest: compounds 1 and 2 (each within the scatter of the next); then compound 3; then compound 4.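

On the carbonyl carbon, methyl(3-methylbenzyl)amino gives the highest number in the series in this assay, with a 7.0-fold higher number from compound 1 to compound 4 (0.84 log units; beyond the scatter) and a 6.5-fold higher number from compound 2 to compound 4 (0.81 log units; beyond the scatter), and it also stands clear of the earlier high point, with a 2.1-fold higher number from compound 3 to compound 4 (0.33 log units; beyond the scatter). Compound 1 and compound 4 both lack the amide hydrogen, yet their numbers lie well apart, so the absence of that hydrogen does not by itself hold the number low. No measurement at hand accounts for the rise.

The compounds shown leave open how methyl(benzyl)amino and ethyl(3-methylbenzyl)amino would read, and so how the rise divides between the shorter chain on nitrogen and the ring methyl. Also open, on these data alone, is whether (3-chlorobenzyl)amino would read closer to compound 2 or compound 3.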